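The source may report more compounds than this note shows. Statements on the series, on what has been measured and on what is new or still open speak of the compounds shown alone.

The measured compounds:
Compound 1, `COc1cc(-c2cc(/C=C/C(=O)c3ccc(Cl)c(Cl)c3)[nH]n2)cc(OC)c1OC`. In a functional assay on SN12C cells (Homo sapiens) for inhibition, read by sulforhodamine B assay, with a stated time of 48 h (a lower number here means a stronger inhibitor of growth, a higher number a weaker inhibitor of growth), compound 1 gives > 100000 nM, which is a limit of the assay rather than a number.
Compound 2, `COc1ccc(C(=O)/C=C/c2cc(-c3cc(OC)c(OC)c(OC)c3)n[nH]2)cc1OC`. In this assay compound 2 gives 3130 nM.

Among the compounds with values here, compound 2 therefore holds the only number in this assay; the other value shown is the limit of > 100000 nM in this assay, at which 1 of the 2 values shown sits, so no finer comparison between the two is possible. Compound 3, `COc1cc(-c2cc(/C=C/C(=O)c3ccc(F)c(F)c3)[nH]n2)cc(OC)c1OC`, differs from compound 2 in one place: 3,4-difluorophenyl in place of 3,4-dimethoxyphenyl on a carbonyl carbon. Within the data shown here, the single measured step, an at least 31-fold lower number from compound 1 to compound 2 (1.50 log units; beyond the scatter), ran from a dihalogenated phenyl on that carbonyl carbon to the 3,4-dimethoxyphenyl and brought a large gain in growth inhibition. The change to compound 3 runs the other way, the dimethoxyphenyl leaving and a dihalogenated phenyl entering, though with fluorine rather than chlorine, which the measured pair does not cover. A large step toward weaker growth inhibition is therefore expected, a 13-fold higher number from compound 2 to compound 3 (1.11 log units; beyond the scatter), with a real chance that only a limit is reported. The estimate for compound 3 is 40000 nM, ranging from 6000 nM to 150000 nM.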

Compound 3, concentration for total growth inhibition: 25500 nM
Compound 3: middle estimate off by 1.6-fold (0.20 log units), on the high side; measured number inside the range.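

Replacing the 3,4-dimethoxyphenyl on the carbonyl carbon with 3,4-difluorophenyl gives an 8.1-fold higher number from compound 2 to compound 3 (0.91 log units; beyond the scatter), so the loss of growth inhibition seen with 3,4-dichlorophenyl at this place also appears with fluorine, and the 3,4-dimethoxyphenyl remains the best of the three groups in this assay. The two halogens are not interchangeable either, with an at least 3.9-fold lower number from compound 1 to compound 3 (0.59 log units; beyond the scatter) when 3,4-difluorophenyl replaces 3,4-dichlorophenyl, which places compound 3 between the other two compounds. The true size of this last step stays unknown, and the printed size is only a bound, since compound 1 carries a limit of the assay and not a number: the limit of > 100000 nM in this assay, at which 1 of the 3 values shown sits.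

All three compounds share one core and vary only in the group on the carbonyl carbon, so these results say nothing about changes elsewhere in the molecule. On these data alone, whether a phenyl with a single methoxy, a 3,4-dihydroxyphenyl or a phenyl carrying an amine could match the 3,4-dimethoxyphenyl remains open, as does whether an open alkyl chain would be tolerated in place of the aromatic ring.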